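The compounds below may be only part of what the source reports. "The series", "measured", "known", "first", "only" and "open" are said of these compounds alone.

Measured in a functional assay on HCT-116 cells (Homo sapiens) for inhibition; a lower number here means a stronger inhibitor, a higher number a weaker inhibitor:
compound 1 `CCCNCc1cc(-c2c(C(=O)NCC)noc2-c2cc(C(C)C)c(O)cc2O)on1` gives 117 nM
compound 2 `CCNC(=O)c1noc(-c2cc(C(C)C)c(O)cc2O)c1-c1cc(CN2CCCCC2)no1` gives 93 nM

Among the measured compounds shown here, compound 1 carries the highest of the two numbers so far, but the gap to the other is within the scatter: a 1.3-fold lower number from compound 1 to compound 2 (0.10 log units; within the scatter). That single step swaps piperidin-1-yl for propylamino on a saturated chain carbon bound to an aromatic carbon and keeps the ring that carries the chain.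

Compound 3 `CCNC(=O)c1noc(-c2cc(C(C)C)c(O)cc2O)c1-c1cc[nH]n1` is not yet measured. Relative to compound 1 it shows (1H-pyrazol-3-yl in place of 3-((propylamino)methyl)-1,2-oxazol-5-yl on an aromatic carbon). The whole 3-((propylamino)methyl)-1,2-oxazol-5-yl group is removed and 1H-pyrazol-3-yl takes its place on that aromatic carbon of the shared core. For the measured compounds named here, no measured step covers loss of the ring together with its chain, because a 1.3-fold lower number from compound 1 to compound 2 (0.10 log units; within the scatter) only varies the amine on the chain. The change is thus larger than anything measured, and a weaker inhibitor is expected, with a wide range. Compound 3 is estimated at 450 nM (range 120 nM to 2500 nM), an expected step of a 3.8-fold higher number from compound 1 to compound 3 (0.59 log units; beyond the scatter).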

Compound 3, half-maximal inhibitory concentration: 36 nM
Estimate against measurement, compound 3: 13-fold (1.10 log units) above; the measured number lies below the stated range.
By their numbers in this assay, from the lowest: compound 3; then compounds 2 and 1 (each within the scatter of the next).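

In this assay, the exchange of 3-((propylamino)methyl)-1,2-oxazol-5-yl for 1H-pyrazol-3-yl gives a 3.3-fold lower number from compound 1 to compound 3 (0.51 log units; beyond the scatter), so this aromatic carbon of the shared core does not need the propylamino chain or its ring for inhibition at this level. The earlier step, a 1.3-fold lower number from compound 1 to compound 2 (0.10 log units; within the scatter), varied only the amine on the chain and kept the ring, whereas this change replaces the whole group and gives a difference beyond the scatter, with fewer heavy atoms entering than leave and one five-membered aromatic ring with 2 hetero atoms on both sides. No supporting data at hand bear on why the smaller group gives the lower number.

Ring and chain change together in this step, so the share of each in the difference remains unresolved. On these data alone, a plain 1,2-oxazol-5-yl group without the chain, or a 1H-pyrazol-3-yl group carrying the propylaminomethyl chain, would separate the two contributions, and the tolerance of this position for a simple phenyl ring also remains open.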